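Swapping the methylcarbamoyl for a hydroxymethyl

The compounds below may be only part of what the source reports. "The series", "measured", "known", "first", "only" and "open" are said of these compounds alone.

Compound 1 `CCCCCn1c(=O)c2c(ncn2C2O[C@H](C(=O)NC)[C@@H](O)[C@H]2O)n(CCCCC)c1=O` gives 11200 nM in an assay on membranes from brain for displacement of a labelled ligand from adenosine receptor A1 (Rattus norvegicus) (on this read-out higher numbers stand for weaker inhibition and lower numbers for stronger inhibition), the lower of the two numbers recorded; compound 2 `CCCn1c(=O)c2c(ncn2C2O[C@H](CO)[C@@H](O)[C@H]2O)n(CCC)c1=O` gives 15900 nM in this assay, and the two lie within the scatter of each other. Compound 3 `CCCCCn1c(=O)c2c(ncn2C2O[C@H](CO)[C@@H](O)[C@H]2O)n(CCCCC)c1=O` carries hydroxymethyl in place of methylcarbamoyl on a saturated ring carbon. For the measured compounds named here, no measured pair shows this exact change, so the step from compound 1 to compound 3 is expected to stay within the scatter, with a 1.3-fold higher number from compound 1 to compound 3 (0.13 log units; within the scatter) as the estimate. Compound 3 is therefore expected to give about 15000 nM in this assay, with a range from 5000 nM to 45000 nM.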

Compound 3, inhibition constant: 8790 nM
Compound 3: the middle estimate sits 1.7-fold (0.23 log units) above what was measured; low and high end bracket the measured number.
By their numbers in this assay, from the lowest: compounds 3, 1 and 2 (each within the scatter of the next).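

On the core of compound 1, placing hydroxymethyl in place of methylcarbamoyl on a saturated ring carbon gives a 1.3-fold lower number from compound 1 to compound 3 (0.11 log units; within the scatter) in this assay. For the compounds shown here, this is the first direct one-place comparison at this ring carbon next to the ring oxygen, and it shows that, with this core, the exchange leaves the number within the scatter. No available measurement offers a reason for this result. Going by these compounds, whether a carboxylic acid, an aminomethyl group or a longer amide such as ethylcarbamoyl at this ring carbon would also stay within the scatter remains open.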